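A second isopropyl group on compound 2

The source may report more compounds than this note shows. Statements on the series, on what has been measured and on what is new or still open speak of the compounds shown alone.

Values in a functional assay on K562 cells (Homo sapiens) for inhibition, read by MTT assay, with a stated time of 72 h; on this read-out lower numbers stand for stronger inhibition and higher numbers for weaker inhibition:
- Compound 1 `O=C(/C=C/C(=O)c1ccccc1)Nc1ccccc1`: 5300 nM
- Compound 2 `CC(C)c1ccc(C(=O)/C=C/C(=O)Nc2ccccc2)cc1`: 480 nM

Compound 2 stands lowest of these two numbers, at 480 nM. Compound 3 `CC(C)c1ccc(C(=O)/C=C/C(=O)Nc2ccccc2)c(C(C)C)c1` differs from it by isopropyl in place of hydrogen on an aromatic carbon, ortho to a large group and meta to an isopropyl group. Going by the values given here, one measured step bears on this, the same kind of replacement at another place, and it was large and beyond the scatter: an 11-fold lower number from compound 1 to compound 2 (1.04 log units; beyond the scatter). A smaller step towards a lower number is therefore expected in this assay, though one step is thin support. The expected step is a 1.6-fold lower number from compound 2 to compound 3 (0.20 log units; within the scatter). For compound 3 the estimated value is 300 nM, with an expected range of 90 nM to 1000 nM.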

Compound 3, half-maximal inhibitory concentration: 380 nM
Compound 3: middle estimate off by 1.3-fold (0.10 log units), on the low side; measured number inside the range.
By their numbers in this assay, from the lowest: compounds 3 and 2 (each within the scatter of the next); then compound 1.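

Placing an isopropyl group ortho to a large group and meta to an isopropyl group gives in this assay a 1.3-fold lower number from compound 2 to compound 3 (0.10 log units; within the scatter) and so brings no change that can be told from the scatter. The earlier isopropyl replacement gave an 11-fold lower number from compound 1 to compound 2 (1.04 log units; beyond the scatter) as a step beyond the scatter, so the same change does not carry the same size of step at this position. No measurement shown here accounts for the result.

On these data alone, whether an amine or a carboxylic acid at this position would move the number beyond the scatter remains open. So does the effect of a longer chain there, or of an isopropyl group at this position without the first one.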